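Chloro Added to the Aryl Urea of a Thioether Analogue

This account rests on a few compounds, and the source may have more. Where it says the series, first, only, none or still open, it means among the compounds named here.

Measured so far in a functional assay on MGC-803 cells (Homo sapiens) for cytotoxicity, read by MTT assay, with a stated time of 3 days; a higher number here means a weaker inhibitor, a lower number a stronger inhibitor:
Compound 1 `Cc1cc(C)nc(Oc2ccc(NC(=O)Nc3ccc(Cl)cc3)cc2)n1` reaches only the limit of the assay, > 50000 nM, which is not a number.
Compound 2 `Cc1cc(C)nc(Oc2ccc(NC(=O)Nc3ccc(Cl)cc3Cl)cc2)n1` gives 35400 nM.
Compound 3 `Cc1cc(C)nc(Sc2ccc(NC(=O)Nc3ccc(Cl)cc3)cc2)n1` gives 26100 nM.

Compound 2 differs from compound 1 by chloro in place of hydrogen on an aromatic carbon, and that change gave an at least 1.4-fold lower number from compound 1 to compound 2 (0.14 log units; that floor lies within the scatter). Compound 3 carries a different core, and how the cores of compound 1 and compound 3 differ is not broken down here. Compound 4 `Cc1cc(C)nc(Sc2ccc(NC(=O)Nc3ccc(Cl)cc3Cl)cc2)n1` is not yet measured and differs from compound 3 by chloro in place of hydrogen on an aromatic carbon, the same change. The measured step of an at least 1.4-fold lower number from compound 1 to compound 2 (0.14 log units; that floor lies within the scatter) rests on a limit and lies within the scatter, so only a modest shift is expected here. Compound 4 is therefore estimated at 18000 nM, which means a step of a 1.5-fold lower number from compound 3 to compound 4 (0.16 log units; within the scatter). The likely range for compound 4 runs from 7000 nM to 45000 nM.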

Compound 4, half-maximal inhibitory concentration: > 50000 nM
Compound 4: no number, only a limit; the forecaster's own chance of this, stated with the estimate: 10%; at least 2.7-fold (0.44 log units) between middle value and limit.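

In this assay, adding the chloro that gives the 2,4-dichlorophenyl group did not act alike on the two cores: the same change on two cores in this assay, an at least 1.4-fold lower number (0.14 log units; that floor lies within the scatter) from compound 1 to compound 2 and an at least 1.9-fold higher number (0.28 log units; that floor lies within the scatter) from compound 3 to compound 4, at least 2.7-fold (0.43 log units) apart, beyond the scatter of two such steps. Compound 4 reaches only > 50000 nM, a limit of the assay and not a number. From the compounds shown here alone, the steps of an at least 1.9-fold higher number from compound 3 to compound 4 (0.28 log units; that floor lies within the scatter) and an at least 1.4-fold higher number from compound 2 to compound 4 (0.14 log units; that floor lies within the scatter) therefore give only floors, so their true sizes stay unknown and no rule for carrying the change between cores follows: the limit of > 50000 nM in this assay, at which 2 of the 4 values shown sit.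

Going by these compounds, it remains open whether another group in place of that chloro, such as a methoxy group or an amine, would give numbers clear of the limit on both cores.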